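Swapping halogens on the benzyl group of compound 2

This account rests on a few compounds, and the source may have more. Where it says the series, first, only, none or still open, it means among the compounds named here.

Compound 1 `COc1cccc(CNc2ncnc3c2ncn3[C@@H]2O[C@H](CO)[C@@H](O)[C@H]2O)c1`: 7600 nM
Compound 2 `OC[C@H]1O[C@@H](n2cnc3c(NCc4ccc(Cl)c(Cl)c4)ncnc32)[C@H](O)[C@@H]1O`: 3800 nM

Both values come from a functional assay on CCRF-CEM cells (Homo sapiens) for antiproliferative activity, with a stated time of 72 h; on this read-out higher numbers stand for weaker inhibition and lower numbers for stronger inhibition. Within the data shown here, only two compounds have been measured, and compound 2 stands within the scatter of compound 1, so neither can be ranked above the other. Compound 3 `OC[C@H]1O[C@@H](n2cnc3c(NCc4ccc(F)cc4Cl)ncnc32)[C@H](O)[C@@H]1O` remains unmeasured. It differs from compound 2 in one place: 2-chloro-4-fluorophenyl in place of 3,4-dichlorophenyl on a saturated chain carbon bound to a nitrogen on an aromatic ring. Among the measured compounds shown here, one measured step bears on this change. That step, a 2.0-fold lower number from compound 1 to compound 2 (0.30 log units; within the scatter), also exchanged the group on a saturated chain carbon bound to a nitrogen on an aromatic ring, and it stayed within the scatter. For the measured compounds named here, no measured compound carries 2-chloro-4-fluorophenyl, so this evidence is thin. No step beyond the scatter is expected in this assay, and the estimated step is a 1.1-fold higher number from compound 2 to compound 3 (0.02 log units; within the scatter). The estimate for compound 3 is 4000 nM, with an expected range of 1300 nM to 12000 nM.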

Compound 3, half-maximal inhibitory concentration: 20900 nM
For compound 3 the middle estimate is 5.2-fold (0.72 log units) below the measured one; measured number outside the range, above it.
By their numbers in this assay, from the lowest: compounds 2 and 1 (each within the scatter of the next); then compound 3.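

Among these compounds, earlier, the only exchange at this place on a saturated chain carbon bound to a nitrogen on an aromatic ring had stayed within the scatter, so the position could have seemed tolerant of change. In this assay the position proves sensitive: 2-chloro-4-fluorophenyl in place of 3,4-dichlorophenyl gives a 5.5-fold higher number from compound 2 to compound 3 (0.74 log units; beyond the scatter) and, set against 3-methoxyphenyl, it gives a 2.8-fold higher number from compound 1 to compound 3 (0.44 log units; beyond the scatter) as well, so this group gives weaker inhibition than either group measured before it. No measurement shown accounts for this loss.

From the compounds shown here alone, it remains open whether the chlorine or the fluorine of 2-chloro-4-fluorophenyl goes with the higher number, or whether only the two together do. Going by these compounds, how an unsubstituted phenyl group or a longer chain would read at this place also remains open.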